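Butyl on the triple-bonded carbon: compound 4

The compounds below may be only part of what the source reports. "The series", "measured", "known", "first", "only" and "open" are said of these compounds alone.

In a functional assay on MOLT-4 cells (Homo sapiens) for antiproliferative activity, read by MTT assay, with a stated time of 3 days (on this read-out lower numbers stand for stronger inhibition and higher numbers for weaker inhibition), compound 3 (`CCCCCc1ccc(C#Cc2cn(C/C=C\CN3C(=O)c4ccccc4C3=O)c(=O)[nH]c2=O)cc1`) gives 30000 nM. Compound 2 (`CCCCCCCCC#Cc1cn(C/C=C\CN2C(=O)c3ccccc3C2=O)c(=O)[nH]c1=O`) gives 36000 nM, and a 1.2-fold lower number from compound 2 to compound 3 (0.08 log units; within the scatter) keeps the two within the scatter. Compound 1 (`Cc1ccc(C#Cc2cn(C/C=C\CN3C(=O)c4ccccc4C3=O)c(=O)[nH]c2=O)cc1`) gives 266000 nM and stands apart from both: a 7.4-fold lower number from compound 1 to compound 2 (0.87 log units; beyond the scatter) and an 8.9-fold lower number from compound 1 to compound 3 (0.95 log units; beyond the scatter).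

Compound 4 (`CCCCC#Cc1cn(C/C=C\CN2C(=O)c3ccccc3C2=O)c(=O)[nH]c1=O`) follows from compound 3 through (butyl in place of 4-pentylphenyl on a triple-bonded carbon), that is, butyl in place of 4-pentylphenyl on a triple-bonded carbon. Among the measured compounds shown here, no measured step makes this exchange directly. The closest guide is the modest step of an 8.9-fold lower number from compound 1 to compound 3 (0.95 log units; beyond the scatter), where compound 1, with 4-methylphenyl, lacks the butyl of the 4-pentylphenyl group. The octyl of compound 2 also stays close to compound 3, but butyl is a shorter chain than octyl. Three compounds are thin support, so any trend remains tentative.

The expected change is a 3.0-fold higher number from compound 3 to compound 4 (0.48 log units; beyond the scatter), an estimate of modest size toward weaker inhibition. For compound 4 the estimated value is 90000 nM, with an expected range of 30000 nM to 270000 nM.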

Compound 4, half-maximal inhibitory concentration: 41000 nM
Compound 4: middle estimate off by 2.2-fold (0.34 log units), on the high side, and the stated range covers the measured number.
By their numbers in this assay, from the lowest: compounds 3, 2 and 4 (each within the scatter of the next); then compound 1.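

On the triple-bonded carbon, butyl, octyl and 4-pentylphenyl cannot be told apart in this assay, with a 1.4-fold higher number from compound 3 to compound 4 (0.14 log units; within the scatter) and a 1.1-fold higher number from compound 2 to compound 4 (0.06 log units; within the scatter). An aromatic ring in this group is therefore not required to reach this range, and among the compounds shown only the 4-methylphenyl of compound 1 stands apart, with a 6.5-fold lower number from compound 1 to compound 4 (0.81 log units; beyond the scatter). Adding butyl to the group does not have one fixed effect, as it gives a gain on 4-methylphenyl but no readable gain on the butyl chain: the same change on two cores in this assay, an 8.9-fold lower number (0.95 log units; beyond the scatter) from compound 1 to compound 3 and a 1.1-fold lower number (0.06 log units; within the scatter) from compound 4 to compound 2, 7.8-fold (0.89 log units) apart, beyond the scatter of two such steps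

From the compounds shown here alone, whether a chain shorter than butyl, such as propyl, reads with compound 4 or with compound 1 remains open. Going by these compounds, how an amine or a carboxylic acid in place of butyl would read also stays open.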